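The source may hold more compounds than are shown below. What is called first, only, known or untested is meant among the compounds shown, and "the series" means these compounds.

Compound 1 `CCCS(=O)(=O)Nc1ccc(F)c(C(=O)c2n[nH]c3ncc(-c4cccc(C)c4)cc23)c1F` and compound 2 `CCCS(=O)(=O)Nc1ccc(F)c(C(=O)c2n[nH]c3ncc(-c4ccc(Cl)c(Cl)c4)cc23)c1F` share the same core and differ only in the aromatic group hanging from it. In an assay for binding affinity to dual specificity mitogen-activated protein kinase kinase 4 (Homo sapiens), read by KINOMEscan, tested at 100 nM (on this read-out lower numbers stand for a stronger effect and higher numbers for a weaker effect at the one concentration tested), compound 1 gives 15%, while compound 2 gives 45%, the higher of the two numbers and therefore the weaker binding. Among the measured compounds shown here, the step of a number 30 percentage points higher from compound 1 to compound 2 (beyond the scatter) is the only measured step. Compound 3 `CCCS(=O)(=O)Nc1ccc(F)c(C(=O)c2n[nH]c3ncc(-c4ccc(Cl)c(C(F)(F)F)c4)cc23)c1F` keeps the core of compound 2 and alters one group: trifluoromethyl in place of chloro on an aromatic carbon. For the measured compounds named here, no measured step mirrors this exchange, so the expected step of a number 5 percentage points higher from compound 2 to compound 3 (within the scatter) is taken to be small, with wide uncertainty. Compound 3 is estimated at 50%, within 25% to 80%.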

Compound 3, a percentage reported as activity, at one concentration (the size of the read-out at that concentration, not a potency): 15%
Estimate against measurement, compound 3: 35 percentage points above; the measured number lies below the stated range.
By their numbers in this assay, from the lowest: compounds 1 and 3 (each within the scatter of the next); then compound 2.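

Trifluoromethyl in place of chloro gives a number 30 percentage points lower from compound 2 to compound 3 (beyond the scatter) in this assay, so keeping one chloro group on this ring does not by itself bring the higher number seen with 3,4-dichlorophenyl. Replacing 3-methylphenyl with 4-chloro-3-(trifluoromethyl)phenyl gives no change at the digits printed from compound 1 to compound 3 (within the scatter), so these two groups cannot be told apart in this assay. Among the compounds shown here, nothing available explains why the single exchange shifts the number. On these data alone, whether a nitrile or a methoxy group at this place would also give the lower number remains open, as does whether trifluoromethyl would do so without the chloro group.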